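A few compounds are considered here, and "the series" means these few. Any claim that something is new, unique, unknown or untested is made for them only; others in the source may bear on it.

Working notes on a short amide series sharing one core. Compound 1 `CN(C)c1ccc2cc(NC(=O)CCc3ccc(C(F)(F)F)cc3)ccc2n1` gives 13 nM in an assay on isolated protein for displacement of a labelled ligand from melanin-concentrating hormone receptor 1 (Homo sapiens); on this read-out higher numbers stand for weaker inhibition and lower numbers for stronger inhibition. Compound 2 `CC(C)N(C)c1ccc2cc(NC(=O)CCc3ccc(C(F)(F)F)cc3)ccc2n1` gives 2 nM in this assay; the step is a 6.5-fold lower number from compound 1 to compound 2 (0.81 log units; beyond the scatter), isopropyl in place of methyl on a nitrogen on an aromatic ring. Compound 3 `O=C(CCc1ccc(C(F)(F)F)cc1)Nc1ccc2nc(N3CCC(c4ccccc4)C3)ccc2c1`, carrying 3-phenylpyrrolidin-1-yl in place of dimethylamino on an aromatic carbon, gives 25 nM in this assay. Its number is the highest of the three shown, but the picture is uneven: a 1.9-fold higher number from compound 1 to compound 3 (0.28 log units; within the scatter), whereas a 13-fold higher number from compound 2 to compound 3 (1.10 log units; beyond the scatter).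

Compound 4 `O=C(CCc1ccc(C(F)(F)F)cc1)Nc1ccc2nc(N3CC4CCC3C4)ccc2c1` is not yet measured. The change from compound 3 is a group of 7 heavy atoms (6 carbon, 1 nitrogen; one five-membered non-aromatic ring of carbon only, one five-membered non-aromatic ring with 1 hetero atom) in place of a group of 11 heavy atoms (10 carbon, 1 nitrogen; one five-membered non-aromatic ring with 1 hetero atom, one six-membered aromatic ring of carbon only), on an aromatic carbon. Among the measured compounds shown here, the steps that bear on it are the two at this same aromatic carbon, a 1.9-fold higher number from compound 1 to compound 3 (0.28 log units; within the scatter) and a 13-fold higher number from compound 2 to compound 3 (1.10 log units; beyond the scatter): both compounds with a small dialkylamino group at that carbon give the lower numbers, and the group entering compound 4, by what is counted, sits between those groups and 3-phenylpyrrolidin-1-yl in size. For compound 4 a modest downward step in this assay is therefore expected, a 3.1-fold lower number from compound 3 to compound 4 (0.49 log units; beyond the scatter), with a result within the scatter of compound 3 not excluded. Compound 4 is estimated at 8 nM in this assay, with a range from 2 nM to 30 nM.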

Compound 4, half-maximal inhibitory concentration: 1 nM
Beside the measured number, compound 4's estimate is 8.0-fold (0.90 log units) above it; measured number below the stated range.
By their numbers in this assay, from the lowest: compounds 4 and 2 (each within the scatter of the next); then compounds 1 and 3 (each within the scatter of the next).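

In this assay a ring-bearing amine on this aromatic carbon is compatible with a low number, and the outcome depends strongly on which ring group is present: replacing 3-phenylpyrrolidin-1-yl with the group of 7 heavy atoms gives a large step (a 25-fold lower number from compound 3 to compound 4 (1.40 log units; beyond the scatter)). The same group also gives a large step against the dimethylamino group (a 13-fold lower number from compound 1 to compound 4 (1.11 log units; beyond the scatter)), but cannot be separated from isopropyl(methyl)amino (a 2.0-fold lower number from compound 2 to compound 4 (0.30 log units; within the scatter)), so two quite different groups at this carbon reach the same level. Across compounds 1, 2 and 4 the number falls as the heavy-atom count of the group rises, compound 3 goes against that trend with the largest group and the highest number, and no measurement shown accounts for any of this.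

Going by these compounds, whether the low number of compound 4 needs both of its rings stays open, since neither unsubstituted pyrrolidin-1-yl nor piperidin-1-yl appears. Also open, on these data alone, is how this carbon tolerates a ring with a second hetero atom, such as morpholin-4-yl, or a hydroxyl on the ring.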